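Working notes: from compound 2 to compound 4

The source may report more compounds than this note shows. Statements on the series, on what has been measured and on what is new or still open speak of the compounds shown alone.

- compound 1 `O=C1CS/C(=N/Nc2nncc3ccccc23)N1c1ccccc1` – 77 nM
- compound 2 `Cc1cc(C)nc(NS(=O)(=O)c2ccc(Nc3nncc4ccccc34)cc2)n1` – 7.7 nM
- compound 3 `Fc1ccc(Nc2nncc3ccccc23)cc1` – 3.5 nM

All three values come from a functional assay on MCF7 cells (Homo sapiens) for antiproliferative activity, read by sulforhodamine B assay, with a stated time of 72 h; on this read-out higher numbers stand for weaker inhibition and lower numbers for stronger inhibition. Compound 2 holds the second highest of the three numbers, and its gaps to compound 3 and to compound 1 both lie beyond the scatter. Compound 4 `O=S(=O)(Nc1ccccn1)c1ccc(Nc2nncc3ccccc23)cc1` differs from compound 2 in one place: pyridin-2-yl in place of 4,6-dimethylpyrimidin-2-yl on a sulfonamide nitrogen. Among the compounds with values here, no measured pair shows this change, so the data give no direct guide to its size. No step beyond the scatter is expected. The estimated change is a 1.2-fold higher number from compound 2 to compound 4 (0.07 log units; within the scatter). For compound 4 the expected value is 9 nM, with an estimated range of 3 nM to 30 nM.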

Compound 4, half-maximal inhibitory concentration: 53 nM
Estimate against measurement, compound 4: 5.9-fold (0.77 log units) below, outside the stated range (above it).
By their numbers in this assay, from the lowest: compound 3; then compound 2; then compounds 4 and 1 (each within the scatter of the next).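

Within the data shown here, on a sulfonamide nitrogen, pyridin-2-yl in place of 4,6-dimethylpyrimidin-2-yl gives a 6.9-fold higher number from compound 2 to compound 4 (0.84 log units; beyond the scatter) in this assay and is the first single-place step. It shows that this group alone can move the number beyond the scatter. The data offer no measurement that accounts for the step.

On these data alone, the two groups differ both in the ring nitrogen count and in the two methyl groups, so the contribution of each stays open. A pyrimidin-2-yl or 4,6-dimethylpyridin-2-yl group on the same nitrogen would separate the two.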